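Chloro for Fluoro on the Pendant Aromatic Ring

The compounds below may be only part of what the source reports. "The series", "measured", "known", "first", "only" and "open" are said of these compounds alone.

The series shares a common core carrying a second aromatic ring on the amide nitrogen. Compound 1 `COc1ccc(N2C(=O)COc3ccc(-c4cnc5ccccc5c4)cc32)cc1` is its simplest member. In a functional assay on MCF7 cells (Homo sapiens) for antiproliferative activity, read by MTT assay, with a stated time of 72 h (a higher number here means a weaker inhibitor, a lower number a stronger inhibitor), compound 1 gives only a limit, > 40000 nM. Compound 2 `O=C1COc2ccc(-c3cnc(Cl)c(NS(=O)(=O)c4ccc(F)cc4)c3)cc2N1c1ccc(F)cc1` adds a sulfonamide-bearing pyridine and in this assay gives 32600 nM. Compound 3 `COc1ncc(-c2ccc3c(c2)N(c2ccc(F)cc2)C(=O)CO3)cc1NS(=O)(=O)c1ccc(F)cc1` replaces the chloro of compound 2 with methoxy on an aromatic carbon. In this assay compound 3 likewise returns a limit, > 40000 nM. The step of an at least 1.2-fold higher number from compound 2 to compound 3 (0.08 log units; that floor lies within the scatter) is therefore only a floor, and compound 3 stands at the weak end of the numbers shown, sharing the limit of > 40000 nM in this assay, at which 2 of the 3 values shown sit, with compound 1.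

Compound 4 `COc1ncc(-c2ccc3c(c2)N(c2ccc(Cl)cc2)C(=O)CO3)cc1NS(=O)(=O)c1ccc(F)cc1` differs from compound 3 by chloro in place of fluoro on an aromatic carbon; read one bond further out, 4-fluorophenyl becomes 4-chlorophenyl. For the measured compounds named here, no measured step touches this ring, so nothing in the data speaks directly to the change. Going by the values given here, the one measured step, from compound 2 to compound 3, sits on the other aromatic ring and is itself within the scatter. Compound 4 is therefore expected to show no movement beyond the scatter, a number no higher from compound 3 to compound 4 (the limit leaves the size open), and most probably to return a limit as compound 3 did. The estimate for compound 4 in this assay is 40000 nM, ranging from 20000 nM to 80000 nM.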

Compound 4, half-maximal inhibitory concentration: 27600 nM
Compound 4: the middle estimate sits 1.4-fold (0.16 log units) above what was measured, within the range that was stated.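

For the compounds shown here, the first change at this position, 4-fluorophenyl to 4-chlorophenyl, with the methoxy group kept in place, turns a limit into a measured number in this assay; the step is an at least 1.4-fold lower number from compound 3 to compound 4 (0.16 log units; that floor lies within the scatter). Going by these compounds alone, the true size of this step stays open because compound 3 is one of the compounds held at a limit: the limit of > 40000 nM in this assay, at which 2 of the 4 values shown sit. The position can therefore be read in this assay for the first time, and a single halogen swap on this ring takes a compound off the limit, but nothing printed places that move beyond the scatter.

Going by these compounds, only fluoro and chloro appear at this position, so it remains open how a bromo, a trifluoromethyl, an amine or a carboxylic acid would read there, and whether any group at this place can move the number beyond the scatter. On these data alone, it also remains open whether 4-chlorophenyl would read the same alongside the chloro of compound 2 as it does alongside the methoxy of compound 3.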